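Para-Substituent Swap on the Benzylamine Arm

The compounds below may be only part of what the source reports. "The series", "measured", "known", "first", "only" and "open" are said of these compounds alone.

Compound 1 `O=S(=O)(NCCCNCc1ccc(Cl)cc1)c1cc(C(F)(F)F)cc(C(F)(F)F)c1`: 2700 nM
Compound 2 `O=S(=O)(NCCCNCc1ccccc1Cl)c1cc(C(F)(F)F)cc(C(F)(F)F)c1`: 13000 nM

In a functional assay on Capan-2 cells (Homo sapiens) for inhibition, read by MTT assay, with a stated time of 72 h (on this read-out higher numbers stand for weaker inhibition of growth and lower numbers for stronger inhibition of growth), compound 1 gives 2700 nM, the lowest of the two numbers; its nearest neighbour is compound 2, measured at 13000 nM, and the step of a 4.8-fold higher number from compound 1 to compound 2 (0.68 log units; beyond the scatter) is the only one recorded. Compound 3 `O=S(=O)(NCCCNCc1ccc(-c2ccccc2)cc1)c1cc(C(F)(F)F)cc(C(F)(F)F)c1` has not yet been measured. It differs from compound 1 by phenyl in place of chloro on an aromatic carbon, the phenyl sitting para to a large group. Going by the values given here, the one measured step concerns a move of the chloro group rather than its replacement, so no recorded step bears directly on this change. With nothing to show either a gain or a loss, a step in this assay of no more than the scatter is expected, in either direction. Compound 3 is therefore estimated at 2200 nM, within 600 nM to 8000 nM, which would mean a 1.2-fold lower number from compound 1 to compound 3 (0.09 log units; within the scatter).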

Compound 3, concentration for 50% growth inhibition: 2200 nM
Estimate against measurement, compound 3: no gap at the digits printed; low and high end bracket the measured number.
By their numbers in this assay, from the lowest: compounds 3 and 1 (each within the scatter of the next); then compound 2.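

In this assay, phenyl in place of chloro on this aromatic carbon gives a 1.2-fold lower number from compound 1 to compound 3 (0.09 log units; within the scatter), so a group of six heavy atoms with its own six-membered aromatic ring, entering where a single chlorine stood, makes no readable difference here. Going by these compounds alone, until now the only recorded step concerned where the chloro group sits on the ring, and it said nothing about what else this place would accept. Nothing measured on these compounds accounts for this result.

As far as these compounds go, whether a methoxy group, an amine or a carboxylic acid at this place would also leave the number within the scatter remains open. So does whether phenyl would match chloro at the place the chlorine occupies in compound 2.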